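From Chloro to Phenyl: Estimating the Cytotoxicity of Compound 4

The compounds below may be only part of what the source reports. "The series", "measured", "known", "first", "only" and "open" are said of these compounds alone.

Of the compounds shown here, three sharing one core have been tested in an ADME assay on A549 cells (Homo sapiens) for cytotoxicity, read by CellTiter-Glo; on this read-out lower numbers stand for higher toxicity in this test and higher numbers for lower toxicity in this test. Compound 1 `Cc1c(Cc2ccccc2)c(=O)oc2cc(OCC(O)CNCc3cccs3)ccc12` gives 87300 nM, and compound 3 `CC(=O)C1CCN(CC(O)COc2ccc3c(C)c(Cc4cccc([N+](=O)[O-])c4)c(=O)oc3c2)CC1` gives 90500 nM; these two numbers lie within the usual scatter of each other. Compound 2 `Cc1c(Cc2ccc(Cl)cc2)c(=O)oc2cc(OCC(O)CN3CCC(C(N)=O)CC3)ccc12` gives 40000 nM, the lowest of the three numbers and beyond the scatter from both others. Compound 4 `Cc1c(Cc2ccc(-c3ccccc3)cc2)c(=O)oc2cc(OCC(O)CN3CCC(C(N)=O)CC3)ccc12` has not yet been measured. It differs from compound 2 by phenyl in place of chloro on an aromatic carbon. Within the data shown here, no two measured compounds differ in a single place, so no measured step shows what this kind of change does here. The expected step in this assay is a 1.6-fold lower number from compound 2 to compound 4 (0.20 log units; within the scatter), a modest move toward a lower number, although a change inside the scatter would not surprise. Compound 4 is estimated at 25000 nM, with a likely range from 8000 nM to 80000 nM.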

Compound 4, half-maximal cytotoxic concentration: > 100000 nM
Compound 4 gave a limit, no number; the forecaster's own chance of this, stated with the estimate: 10%; middle value at least 4.0-fold (0.60 log units) away from the limit.
By their numbers in this assay, from the lowest: compound 2; then compounds 1 and 3 (each within the scatter of the next). At a limit, above all of these: compound 4.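

For compound 4 the result is a limit, not a number: the limit of > 100000 nM in this assay, at which 1 of the 4 values shown sits. In this assay, phenyl in place of chloro, on an aromatic carbon para to a large group, gives an at least 2.5-fold higher number from compound 2 to compound 4 (0.39 log units; beyond the scatter). This is the only single-place step shown, and it runs toward a higher number, so at this position the larger ring brings no sign of higher toxicity in this test.

Going by these compounds, how far the step really reaches stays unknown. Also open, on these data alone, is what an amine or a carboxylic acid would do at this same carbon, or whether phenyl acts alike with the side chains of compound 1 or compound 3.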